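A few compounds are considered here, and "the series" means these few. Any claim that something is new, unique, unknown or untested is made for them only; others in the source may bear on it.

Compound 2, `CC1(C)Oc2ccc(C#N)cc2[C@@H](N2CCCCC2=O)[C@@H]1O`, is the reference point here. In a functional assay (trachea) for inhibition, with Cavia porcellus as the target (on this read-out higher numbers stand for weaker inhibition and lower numbers for stronger inhibition), compound 2 gives 270 nM, the lowest of the two numbers in this set. Its nearest neighbour is compound 3, `CCc1ccc2c(c1)[C@@H](N1CCCC1=O)[C@H](O)C(C)(C)O2`, which in this assay gives 2680 nM, a gap that lies beyond the scatter. Compound 1, `CC1(C)Oc2ccc(C#N)cc2[C@@H](N2CCC2=O)[C@@H]1O`, has no number in this assay but only a limit, > 20000 nM. That limit, (the limit of > 20000 nM in this assay, at which 1 of the 3 values shown sits), is the only one in the set. Within the data shown here, the single step between measured compounds that differ in one place is an at least 74-fold lower number from compound 1 to compound 2 (1.86 log units; beyond the scatter); it concerns the lactam ring attached to a saturated ring carbon, not the aromatic substituent.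

Compound 4, `CC1(C)Oc2ccc(C(F)(F)F)cc2[C@@H](N2CCCCC2=O)[C@@H]1O`, is not yet measured. It differs from compound 2 by trifluoromethyl in place of cyano on an aromatic carbon. Among the measured compounds shown here, no measured step changes this aromatic position alone, so nothing in the data speaks directly for or against the new group. Compound 3 carries an ethyl at the same position but also a different lactam ring, so its value and that of compound 2 cannot be separated into two effects. The expected step is therefore a 1.7-fold higher number from compound 2 to compound 4 (0.22 log units; within the scatter), a cautious estimate with a wide range. Compound 4 is expected to give 450 nM in this assay, between 100 nM and 2500 nM.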

Compound 4, half-maximal inhibitory concentration: 58 nM
Compound 4: middle estimate off by 7.8-fold (0.89 log units), on the high side; the whole stated range lies above it.
By their numbers in this assay, from the lowest: compound 4; then compound 2; then compound 3. At a limit, above all of these: compound 1.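

Among these compounds, with the 2-oxopiperidin-1-yl lactam held fixed, this is the first measured step that changes the aromatic substituent alone, and in this assay it gives a 4.7-fold lower number from compound 2 to compound 4 (0.67 log units; beyond the scatter). The aromatic carbon is therefore a place where the choice of group shows up in the read-out, and the nitrile is not needed there for a number in this range, since trifluoromethyl, which carries no triple bond, gives the lowest number of the set. The step is still much smaller than the one seen on changing the lactam ring, an at least 74-fold lower number from compound 1 to compound 2 (1.86 log units; beyond the scatter), and no measurement given here shows what lies behind the gain from trifluoromethyl.

Among the compounds shown here, only two groups can be compared at this aromatic carbon with the lactam unchanged, so it remains open how a chlorine atom, an amine, a carboxylic acid or a longer chain would behave there, and how the ethyl of compound 3 would compare on the same lactam as compound 4. On these data alone, it also remains open whether trifluoromethyl would bring a similar step on the lactam ring of compound 3, which would show whether the two changes act independently of each other.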